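The compounds below may be only part of what the source reports. "The series", "measured", "known", "first", "only" and "open" are said of these compounds alone.

Measured in a functional assay on HCT-116 cells (Homo sapiens) for antiproliferative activity, read by MTT assay, with a stated time of 72 h; a lower number here means a stronger inhibitor, a higher number a weaker inhibitor:
- compound 1 `NC1=NC2(CCSCC2)N(OCCCOc2ccc(Br)cc2)C(N)=N1`: 20 nM
- compound 2 `NC1=NC2(CCOCC2)N(OCCCOc2cccc(Cl)c2Cl)C(N)=N1`: 5 nM
- compound 3 `NC1=NC2(CCSCC2)N(OCCCOc2cccc(Cl)c2Cl)C(N)=N1`: 1 nM

Compound 3, at 1 nM, has the lowest number of the three. Compound 2, at 5 nM, and compound 1, at 20 nM, both stand higher, beyond the scatter.

The next compound is compound 4 `NC1=NC2(CCSCC2)N(OCCCOc2ccccc2Br)C(N)=N1`, with 2-bromophenyl in place of 2,3-dichlorophenyl on an oxygen on a saturated carbon. The shared core stays as in compound 3.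

Going by the values given here, only one measured step bears on this place: a 20-fold lower number from compound 1 to compound 3 (1.30 log units; beyond the scatter), a large step beyond the scatter, with 2,3-dichlorophenyl in place of 4-bromophenyl. Compound 2 carries the same 2,3-dichlorophenyl as compound 3 and differs only in the core, so it says nothing about the change here. Among the compounds with values here, no 2-bromophenyl compound has been measured, and one step cannot separate the two chlorines from the place of the bromine.

Compound 4 gives up the 2,3-dichlorophenyl of the lowest number but is not the 4-bromophenyl of compound 1, so it is expected to land between the two. The expected change in this assay is a 5.0-fold higher number from compound 3 to compound 4 (0.70 log units; beyond the scatter), towards a higher number and smaller than the measured step.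

The estimate for compound 4 is 5 nM, with an expected range of 1.5 nM to 20 nM.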

Compound 4, half-maximal inhibitory concentration: 1 nM
Estimate against measurement, compound 4: 5.0-fold (0.70 log units) above; measured number below the stated range.
By their numbers in this assay, from the lowest: compounds 3 and 4 (each within the scatter of the next); then compound 2; then compound 1.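

In this assay, the step of no change at the digits printed from compound 3 to compound 4 (within the scatter) shows that at this place, on an oxygen on a saturated carbon, 2-bromophenyl serves as well as 2,3-dichlorophenyl, so the two chlorines are not required to hold the number of compound 3. The step of a 20-fold lower number from compound 1 to compound 4 (1.30 log units; beyond the scatter) keeps one bromine on the ring and exchanges only 4-bromophenyl for 2-bromophenyl, so the place of the bromine alone accounts for a large step, a separation that the earlier comparison of 4-bromophenyl with 2,3-dichlorophenyl could not make. No supporting data bear on why the place of the bromine matters in this series.

Still open, from the compounds shown here alone, is how 3-bromophenyl, 2-chlorophenyl or plain phenyl would compare at this place, and so whether any halogen is needed here at all. Also open, going by these compounds, is whether 2-bromophenyl keeps its number on the core of compound 2, and whether a longer chain between the two oxygens is compatible with either aryl group.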